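From Compound 3 to Compound 4 in Vero Cell Tolerance

A few compounds are considered here, and "the series" means these few. Any claim that something is new, unique, unknown or untested is made for them only; others in the source may bear on it.

Three compounds sharing one core have been examined in an ADME assay on Vero cells (Chlorocebus sabaeus) for cytotoxicity, read by MTT assay, with a stated time of 72 h; a higher number here means that more compound is tolerated, a lower number that less compound is tolerated. Compound 1 `COC(=O)c1cc(-c2cccc(NC(=O)c3ccc(/C=C/C(=O)c4cccc([N+](=O)[O-])c4)cc3)c2)on1` carries a 3-nitrophenyl on a carbonyl carbon; in this assay compound 1 gives > 40 ug/mL, which is a limit of the assay rather than a number. Compound 2 `COC(=O)c1cc(-c2cccc(NC(=O)c3ccc(/C=C/C(=O)c4cc(F)ccc4F)cc3)c2)on1` has 2,5-difluorophenyl in place of 3-nitrophenyl on a carbonyl carbon, and in this assay compound 2 gives > 40 ug/mL, again a limit. Compound 3 `COC(=O)c1cc(-c2cccc(NC(=O)c3ccc(/C=C/C(=O)c4ccc(F)cc4F)cc3)c2)on1` has 2,4-difluorophenyl on a carbonyl carbon, and in this assay compound 3 gives > 40 ug/mL, also a limit. Compound 3 thus stands at the limit of > 40 ug/mL in this assay, at which 3 of the 3 values shown sit. The steps a step that the two limits leave unreadable from compound 1 to compound 2, a step that the two limits leave unreadable from compound 1 to compound 3 and a step that the two limits leave unreadable from compound 2 to compound 3 are all left unreadable by the limits on both sides.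

Compound 4 `CCCOc1ccc(C(=O)/C=C/c2ccc(C(=O)Nc3cccc(-c4cc(C(=O)OC)no4)c3)cc2)cc1` has not yet been measured. It differs from compound 3 as follows: 4-propoxyphenyl in place of 2,4-difluorophenyl on a carbonyl carbon. Among the measured compounds shown here, no measured step bears on this change in readable form; every step among the three measured compounds is hidden by the limits. For the measured compounds named here, the only guide is that each of the three groups tried so far on the carbonyl carbon was tolerated up to the limit. Compound 4 is therefore expected to sit at or near the limit as well, with an estimate of 45 ug/mL and a range from 20 ug/mL to 100 ug/mL. The step that the limit leaves unreadable from compound 3 to compound 4 that this estimate means is expected to be small, though its true size cannot be read.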

Compound 4, half-maximal cytotoxic concentration: > 40 ug/mL
Compound 4: only a limit was reported (the forecaster's own chance of this, stated with the estimate: 70%); the middle value lies beyond the limit too.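

In this assay compound 4 gives > 40 ug/mL, which is a limit and not a number, so no step linking it to compound 1, compound 2 or compound 3 can be read: the limit of > 40 ug/mL in this assay, at which 4 of the 4 values shown sit.

The compounds shown leave open whether the four groups on the carbonyl carbon differ at all in how much compound is tolerated.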